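Swapping methoxy for chloro on compound 1

A few compounds are considered here, and "the series" means these few. Any claim that something is new, unique, unknown or untested is made for them only; others in the source may bear on it.

In a functional assay on cells (Homo sapiens) for antiproliferative activity, read by CellTiter-Glo, with a stated time of 96 h (a lower number here means a stronger inhibitor, a higher number a weaker inhibitor), compound 1 `COc1ccc(-c2nsc3c2NC(=O)CC3c2cccc(OC)c2)cc1` gives 1910 nM while compound 2 `COc1ccc(-c2nsc3c2NC(=O)CC3c2ccc3c(c2)OCCO3)cc1` gives 1360 nM and the two stand level within the usual scatter. Compound 3 `COc1ccc(-c2nsc3c2NC(=O)CC3c2cccc(Cl)c2)cc1` keeps the core of compound 1 but carries chloro in place of methoxy on an aromatic carbon, turning 3-methoxyphenyl into 3-chlorophenyl (chloro in place of methoxy on an aromatic carbon). Among the compounds with values here, no measured pair shows this swap, so the data offer no direct guide. The expected step (a 1.3-fold lower number from compound 1 to compound 3 (0.10 log units; within the scatter)) stays within the scatter in this assay. Compound 3 is estimated at 1500 nM with an expected range from 600 nM to 3500 nM for its measurement.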

Compound 3, half-maximal inhibitory concentration: > 2000 nM
Compound 3: a limit, no number (the forecaster's own chance of this, stated with the estimate: 5%); middle value at least 1.3-fold (0.12 log units) from the limit.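

For compound 3 the reading in this assay is a limit, not a number: the limit of > 2000 nM in this assay, at which 1 of the 3 values shown sits.

Chloro in place of methoxy on an aromatic carbon brings an at least 1.0-fold higher number from compound 1 to compound 3 (0.01 log units; that floor lies within the scatter). Within the data shown here, this is the first look at a change at this place, and it shows that chloro does not lower the number, while the true size of any rise cannot be read.

Still open, from the compounds shown here alone, is how an amine, a hydroxyl or a carboxylic acid on this aromatic carbon would fare in this assay.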